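The source may report more compounds than this note shows. Statements on the series, on what has been measured and on what is new or still open speak of the compounds shown alone.

Compound 1, `CCCN(CCC)S(=O)(=O)c1ccc(S(=O)(=O)N2CCC[C@@H](C(=O)OCC)C2)cc1`, gives 2500 nM in a functional assay on BXPC-3 cells (Homo sapiens) for inhibition, read by MTT assay, with a stated time of 7 days; a lower number here means a stronger inhibitor, a higher number a weaker inhibitor.
Compound 2, `CCOC(=O)[C@@H]1CCCN(S(=O)(=O)c2ccc(S(=O)(=O)N3CCOCC3)cc2)C1`, gives 23400 nM in this assay.
Compound 3, `CCOC(=O)[C@@H]1CCCN(S(=O)(=O)c2ccc(S(=N)(=O)N(CC)CC)cc2)C1`, gives 3600 nM in this assay.

Among these three numbers compound 3 holds the second highest place. Its nearest neighbour is compound 1, and the gap a 1.4-fold higher number from compound 1 to compound 3 (0.16 log units; within the scatter) lies within the usual scatter, so the two cannot be told apart. Its furthest neighbour is compound 2, and the gap a 6.5-fold lower number from compound 2 to compound 3 (0.81 log units; beyond the scatter) is beyond the scatter.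

Compound 4, `CCOC(=O)[C@@H]1CCCN(S(=O)(=O)c2ccc(S(=O)(=O)N(C)C)cc2)C1`, is not yet measured. It differs from compound 3 in one place: a group of 6 heavy atoms (2 carbon, 1 nitrogen, 2 oxygen, 1 sulfur; no ring) in place of a group of 8 heavy atoms (4 carbon, 2 nitrogen, 1 oxygen, 1 sulfur; no ring), on an aromatic carbon. The measured steps that bear on this change all sit at the same aromatic carbon. The swap from a dipropylamino to a morpholin-4-yl on the sulfonyl sulfur cost a 9.4-fold higher number from compound 1 to compound 2 (0.97 log units; beyond the scatter), whereas the swap to the eight-atom group cost only a 1.4-fold higher number from compound 1 to compound 3 (0.16 log units; within the scatter). The dimethylsulfamoyl of compound 4 is a smaller open-chain group than either of those, so the closest guide is the mild loss seen between compound 1 and compound 3 rather than the larger loss seen for compound 2. A modest weakening is therefore expected, a 1.7-fold higher number from compound 3 to compound 4 (0.22 log units; within the scatter), though a result within the scatter would not surprise. For compound 4 the estimate is 6000 nM, with a range from 2000 nM to 20000 nM.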

Compound 4, half-maximal inhibitory concentration: 1000 nM
For compound 4 the middle estimate is 6.0-fold (0.78 log units) above the measured one; measured number outside the range, below it.
By their numbers in this assay, from the lowest: compound 4; then compounds 1 and 3 (each within the scatter of the next); then compound 2.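

In this assay the dimethylsulfamoyl on this aromatic carbon gives the lowest number of the four compounds, and shortening dipropylamino to dimethylamino on the sulfonyl sulfur yields a 2.5-fold lower number from compound 1 to compound 4 (0.40 log units; beyond the scatter) so the longer chains are not needed for activity here. Size alone does not set the order, however: the morpholin-4-yl of compound 2 is smaller than the dipropylamino of compound 1 yet carries the highest number, and replacing it with dimethylamino gives a 23-fold lower number from compound 2 to compound 4 (1.37 log units; beyond the scatter) which is the largest step in the set. Nothing measured here explains why these steps run as they do.

From the compounds shown here alone, the remaining step, a 3.6-fold lower number from compound 3 to compound 4 (0.56 log units; beyond the scatter) changes two things at once, since a group with one hydrogen-bond donor gives way to one with none while the group also shrinks, so the share of each change stays open. A diethylamino on the sulfonyl sulfur would show how the number tracks chain length, and a pyrrolidin-1-yl there would show whether a ring without the morpholine oxygen is tolerated.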